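Replacing the Carboxy Group with Phenoxy

This account rests on a few compounds, and the source may have more. Where it says the series, first, only, none or still open, it means among the compounds named here.

In a functional assay for agonist activity at Free fatty acid receptor 1 (Homo sapiens) (a higher number here means that more compound is needed for the effect, a lower number that less compound is needed), compound 1 `O=C(O)CCc1ccc(NCc2ccc(C(F)(F)F)cc2)cc1` gives 2000 nM. Compound 2 `O=C(O)CCc1ccc(NCc2ccc(C(=O)O)cc2)cc1` reaches only a limit in this assay, < 31700 nM. For the measured compounds named here, the one measured step, a step that the limit leaves unreadable from compound 1 to compound 2, has no readable size because of the limit of < 31700 nM in this assay, at which 1 of the 2 values shown sits. Compound 3 `O=C(O)CCc1ccc(NCc2ccc(Oc3ccccc3)cc2)cc1` carries the change (phenoxy in place of carboxy on an aromatic carbon). Going by the values given here, no measured step shares this change, so the expectation leans on the value of compound 1 alone. Compound 3 is expected to land near 1500 nM, within 400 nM to 6000 nM. The step that the limit leaves unreadable from compound 2 to compound 3 is therefore expected to run toward less compound needed.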

Compound 3, half-maximal effective concentration: 195 nM
For compound 3 the middle estimate is 7.7-fold (0.89 log units) above the measured one, outside the stated range (below it).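

At this aromatic carbon, phenoxy brings a six-membered aromatic ring that neither trifluoromethyl nor carboxy has, and in this assay replacing trifluoromethyl with it gives a 10-fold lower number from compound 1 to compound 3 (1.01 log units; beyond the scatter). The position therefore tolerates an added aromatic ring here, and less compound is needed with it in place. The step from compound 2 to compound 3 cannot be read, so the exchange of carboxy for phenoxy has no size: the limit of < 31700 nM in this assay, at which 1 of the 3 values shown sits.

On these data alone, it remains open whether the ring alone accounts for the drop or the oxygen linking it also matters. A phenyl or benzyl group at this carbon would separate the two.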